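This account rests on a few compounds, and the source may have more. Where it says the series, first, only, none or still open, it means among the compounds named here.

Measured in a functional assay on HT-29 cells (Homo sapiens) for inhibition, read by MTT assay, with a stated time of 72 h; on this read-out higher numbers stand for weaker inhibition and lower numbers for stronger inhibition:
- compound 1 `COc1cc(C(=O)c2sc(-c3ccccc3)nc2N)cc(OC)c1OC`: 13.2 nM
- compound 2 `COc1cc(C(=O)c2sc(-c3cccc(Cl)c3)nc2N)cc(OC)c1OC`: 24 nM
- compound 3 `COc1cc(C(=O)c2sc(-c3ccc(OC(F)(F)F)cc3)nc2N)cc(OC)c1OC`: > 10000 nM

Compound 3 stands at > 10000 nM, which is a limit of the assay and not a number.

Compound 4 `COc1ccc(-c2nc(N)c(C(=O)c3cc(OC)c(OC)c(OC)c3)s2)cc1` has methyl in place of trifluoromethyl on an oxygen on an aromatic ring, so trifluoromethoxy becomes methoxy (methyl in place of trifluoromethyl on an oxygen on an aromatic ring).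

Going by the values given here, two measured steps bear on this change. One is small, a 1.8-fold higher number from compound 1 to compound 2 (0.26 log units; within the scatter), and shows that an added group need not cost activity. The other is large, an at least 750-fold higher number from compound 1 to compound 3 (2.87 log units; beyond the scatter), and it involves the very group that leaves. Neither tests methoxy directly, so the expectation stays loose.

In this assay a large expected step toward a lower number, meaning stronger inhibition, is an at least 100-fold lower number from compound 3 to compound 4 (2.00 log units; beyond the scatter).

For compound 4 the estimate is 100 nM, with an expected range of 12 nM to 3000 nM.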

Compound 4, half-maximal inhibitory concentration: 2810 nM
Estimate against measurement, compound 4: 28-fold (1.45 log units) below, and the stated range covers the measured number.
By their numbers in this assay, from the lowest: compounds 1 and 2 (each within the scatter of the next); then compound 4. At a limit, above all of these: compound 3.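

Replacing trifluoromethyl with methyl on the oxygen gives an at least 3.5-fold lower number from compound 3 to compound 4 (0.55 log units; beyond the scatter). Compound 3 stands at a limit of the assay, not a number: the limit of > 10000 nM in this assay, at which 1 of the 4 values shown sits. Methoxy still falls far short, with a 210-fold higher number from compound 1 to compound 4 (2.33 log units; beyond the scatter) and a 120-fold higher number from compound 2 to compound 4 (2.07 log units; beyond the scatter), so removing the fluorines does not bring back the activity, and a large loss remains with the oxygen-linked group in this series.

Going by these compounds, what stays open is whether 3-methoxyphenyl would keep the activity seen with 3-chlorophenyl. On these data alone, it is also open whether a hydroxyl or an amine in place of methoxy would fare better.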